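A few compounds are considered here, and "the series" means these few. Any claim that something is new, unique, unknown or untested is made for them only; others in the source may bear on it.

For the measured compounds named here, in a functional assay on MCF7 cells (Homo sapiens) for antiproliferative activity, read by sulforhodamine B assay, with a stated time of 48 h (a lower number here means a stronger inhibitor, a higher number a weaker inhibitor), compound 1 (`O=C1NCCN1c1ccc(S(=O)(=O)Nc2ccccc2)cc1`) gives 470 nM and compound 2 (`O=C1NCCN1c1ccc(S(=O)(=O)Nc2cccc(Br)c2)cc1`) gives 100 nM, the lower of the two numbers so far. Compound 3 (`O=C1NCCN1c1ccc(S(=O)(=O)Nc2cccc(Oc3ccccc3)c2)cc1`) carries phenoxy in place of bromo on an aromatic carbon. Going by the values given here, one measured step bears on this place, the modest 4.7-fold lower number from compound 1 to compound 2 (0.67 log units; beyond the scatter), with bromo in place of hydrogen. Among the compounds with values here, no measured compound carries phenoxy, so in this assay no step beyond the scatter is expected, with a slight lean towards a lower number. The estimated change is a 1.4-fold lower number from compound 2 to compound 3 (0.15 log units; within the scatter). For compound 3 the estimated value is 70 nM, with an expected range of 20 nM to 280 nM.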

Compound 3, half-maximal inhibitory concentration: 220 nM
For compound 3 the middle estimate is 3.1-fold (0.50 log units) below the measured one, within the range that was stated.
By their numbers in this assay, from the lowest: compound 2; then compound 3; then compound 1.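

Changing bromo to phenoxy at this aromatic carbon gives a 2.2-fold higher number from compound 2 to compound 3 (0.34 log units; beyond the scatter) in this assay and so places phenoxy behind bromo. Phenoxy still gives a 2.1-fold lower number from compound 1 to compound 3 (0.33 log units; beyond the scatter) against hydrogen, so a group carrying its own aromatic ring keeps part of the gain seen with bromo. Nothing available explains this order of the three groups. As far as these compounds go, whether an amine, a carboxylic acid or methoxy at this carbon would match bromo remains open. So does whether bromo and phenoxy would keep this order at another carbon of the ring.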